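This account rests on a few compounds, and the source may have more. Where it says the series, first, only, none or still open, it means among the compounds named here.

Series notes. Compound 1 `Nc1nc(Cl)c(-c2ncco2)c(N[C@@H]2C[C@H](CO)[C@@H](O)[C@H]2O)n1`, compound 2 `CN(C)c1ccc2sc(-c3c(Cl)nc(N)nc3N[C@@H]3C[C@H](CO)[C@@H](O)[C@H]3O)nc2c1` and compound 3 `CCCNc1nc(C)c(-c2nc3ccccc3s2)c(N[C@@H]2C[C@H](CO)[C@@H](O)[C@H]2O)n1` share one core; compound 4 `CCOC(=O)NCCNc1nc(C)c(-c2nc3ccccc3s2)c(N[C@@H]2C[C@H](CO)[C@@H](O)[C@H]2O)n1` has not yet been measured. The read-out throughout is an ADME assay on cells (Homo sapiens) for cytotoxicity, read by polymerase chain reaction, with a stated time of 3 days; a lower number here means that less compound is tolerated, a higher number that more compound is tolerated. In this assay compound 1 reaches only the limit of the assay, > 25000 nM. In this assay compound 2 gives 25000 nM. In this assay compound 3 likewise returns only the limit, > 25000 nM. Compound 3 thus stands at a limit rather than at a number, and the same holds for (the limit of > 25000 nM in this assay, at which 2 of the 3 values shown sit). The change from compound 3 to compound 4 is (ethoxycarbonyl)amino in place of methyl on a saturated chain carbon, two bonds along the chain from a nitrogen on an aromatic ring. Within the data shown here, no step between two measured compounds has been computed, so the effect of this change cannot be read from measured pairs; the three values shown sit at or near the limit and within the scatter of one another. No shift beyond the usual scatter is expected in this assay, so the step of a number no higher from compound 3 to compound 4 (the limit leaves the size open) is estimated as essentially flat. Compound 4 is expected to give about 25000 nM, within 12000 nM to 50000 nM, most likely reported again only as a limit.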

Compound 4, half-maximal cytotoxic concentration: 12000 nM
Compound 4: the middle estimate sits 2.1-fold (0.32 log units) above what was measured; low and high end bracket the measured number.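

Among these compounds, replacing methyl with (ethoxycarbonyl)amino on a saturated chain carbon, two bonds along the chain from a nitrogen on an aromatic ring, gives the only readable step in this assay: an at least 2.0-fold lower number from compound 3 to compound 4 (0.31 log units; beyond the scatter). The read-out is therefore not indifferent to what this chain carries, and the change goes towards less compound being tolerated. The full size of the step stays open, since its starting point is a limit and not a number: the limit of > 25000 nM in this assay, at which 2 of the 4 values shown sit.

From the compounds shown here alone, it remains open whether a simple amine, a hydroxyl or a carboxylic acid on the same chain carbon would lower the number as well, or whether the (ethoxycarbonyl)amino group is needed. The compounds shown also leave open whether this change would have the same effect on the other compounds of the series.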